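This account rests on a few compounds, and the source may have more. Where it says the series, first, only, none or still open, it means among the compounds named here.

Measured compounds:
compound 1 `CC1=CC[C@H](C(C)(C)NC(=S)N/N=C/c2ccc(O)cc2)CC1`: > 100000 nM
compound 2 `CC1=CC[C@H](C(C)(C)NC(=S)N/N=C/c2ccc(N(C)C)cc2)CC1`: 87000 nM
compound 3 `COc1cc(/C=N/NC(=S)NC(C)(C)[C@H]2CC=C(C)CC2)ccc1O`: 12900 nM

In a functional assay on 786-0 cells (Homo sapiens) for inhibition, read by sulforhodamine B assay, with a stated time of 48 h (on this read-out higher numbers stand for weaker inhibition of growth and lower numbers for stronger inhibition of growth), compound 1 stands at the weak end of the three. The number for compound 1 is a limit of the assay, not a measured value (the limit of > 100000 nM in this assay, at which 1 of the 3 values shown sits). Compound 4 `CC1=CC[C@H](C(C)(C)NC(=S)N/N=C/c2ccco2)CC1` differs from compound 1 in one place: furan-2-yl in place of 4-hydroxyphenyl on a carbon with a double bond to nitrogen. Two measured steps start from compound 1 and both change only a substituent on the ring, not the ring itself: an at least 1.1-fold lower number from compound 1 to compound 2 (0.06 log units; that floor lies within the scatter) and an at least 7.7-fold lower number from compound 1 to compound 3 (0.88 log units; beyond the scatter). Neither step removes the hydroxy group or swaps the aromatic ring, so they bear only loosely on compound 4. Since compound 1 sits at a limit, a lower number for compound 4 cannot be ruled out, but nothing shown points to a large one. The expected step, an at least 1.6-fold lower number from compound 1 to compound 4 (0.22 log units; that floor lies within the scatter), is therefore small. Compound 4 is estimated at 60000 nM, within a range from 15000 nM to 200000 nM.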

Compound 4, concentration for 50% growth inhibition: 11700 nM
Estimate against measurement, compound 4: 5.1-fold (0.71 log units) above, and the stated range ends above it.
By their numbers in this assay, from the lowest: compounds 4 and 3 (each within the scatter of the next); then compound 2. At a limit, above all of these: compound 1.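

In this assay, exchanging the whole ring on the carbon with a double bond to nitrogen, not just a substituent on it, gives an at least 8.5-fold lower number from compound 1 to compound 4 (0.93 log units; beyond the scatter). This shows that the 4-hydroxyphenyl group is not required at this position for growth inhibition, since the smaller furan-2-yl group, with its five-membered aromatic ring and no hydrogen-bond donor, gives a lower number. On these data alone, the true size of the step remains unknown because the number for compound 1 is a limit, not a measured value: the limit of > 100000 nM in this assay, at which 1 of the 4 values shown sits.

Still open, as far as these compounds go, is whether the ring oxygen of furan-2-yl matters, which a thiophen-2-yl or plain phenyl group at the same place could test. From the compounds shown here alone, it is also open whether an amine or a carboxylic acid on the furan-2-yl group would raise or lower the number.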